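A methoxy group added to the anilide of compound 3

The compounds below may be only part of what the source reports. "The series", "measured", "known", "first", "only" and "open" are said of these compounds alone.

Measured compounds:
compound 1, `O=C(/C=C/c1coc2cc(O)ccc2c1=O)NCc1ccccc1`, gives 4690 nM
compound 2, `COc1ccc2c(=O)c(/C=C/C(=O)NCc3ccccc3)coc2c1`, gives 13600 nM
compound 3, `COc1ccc2c(=O)c(/C=C/C(=O)Nc3ccccc3)coc2c1`, gives 9050 nM

In a functional assay on Huh-7 cells (Homo sapiens) for inhibition, read by MTT assay, with a stated time of 48 h (on this read-out higher numbers stand for weaker inhibition and lower numbers for stronger inhibition), compound 3 stands second highest of the three numbers. Its nearest neighbour is compound 2, reached by a 1.5-fold lower number from compound 2 to compound 3 (0.18 log units; within the scatter), and its gap to compound 1 is also within the scatter, so these three compounds cannot be ranked against one another on this assay.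

Compound 4, `COc1cccc(NC(=O)/C=C/c2coc3cc(OC)ccc3c2=O)c1`, differs from compound 3 in one place: methoxy in place of hydrogen on an aromatic carbon. The core and the amide are left as they are.

Going by the values given here, two measured steps bear on this, neither closely. The step of a 1.5-fold lower number from compound 2 to compound 3 (0.18 log units; within the scatter) changed the group on the amide nitrogen and stayed within the scatter. The step of a 2.9-fold higher number from compound 1 to compound 2 (0.46 log units; beyond the scatter) placed a methyl on an oxygen on the shared core and gave a modest rise, beyond the scatter; it is not the same change as adding a methoxy to the six-membered aromatic ring of carbon only. Among the compounds with values here, with no direct precedent, the expected step for compound 4 is small, a 1.2-fold higher number from compound 3 to compound 4 (0.08 log units; within the scatter), not clearly beyond the scatter. Compound 4 is therefore expected to give about 11000 nM in this assay, with a likely range from 4500 nM to 27000 nM.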

Compound 4, half-maximal inhibitory concentration: 11100 nM
The estimate for compound 4 lay 1.0-fold (0.00 log units) below the measured number, and the stated range covers the measured number.
By their numbers in this assay, from the lowest: compounds 1, 3, 4 and 2 (each within the scatter of the next, the first and the last beyond it).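

Going by these compounds alone, the difference from phenyl to 3-methoxyphenyl reads, in this assay, as (a 1.2-fold higher number from compound 3 to compound 4 (0.09 log units; within the scatter)), so this is the first substitution on the anilide ring to be read, and at this aromatic carbon a methoxy does not separate the two compounds. The comparison on the amide nitrogen reads (a 1.2-fold lower number from compound 2 to compound 4 (0.09 log units; within the scatter)), which means that 3-methoxyphenyl cannot be told apart from benzyl here, just as plain phenyl could not. Nothing available speaks to a cause for this result.

What the compounds shown leave open is whether any other group at the same aromatic carbon, such as an amine, a carboxylic acid or a fluorine atom, would move the number beyond the scatter, since methoxy is the only substituent on this ring. Also open, going by these compounds, is whether the free hydroxyl on the shared core, which compound 1 alone carries, would give a different reading when paired with a 3-methoxyphenyl on the amide nitrogen.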